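Ethoxycarbonyl in Place of Nitro on the Urea Aryl Ring

This account rests on a few compounds, and the source may have more. Where it says the series, first, only, none or still open, it means among the compounds named here.

Compound 1 `COc1cc(Nc2ncnc3c(NC(=O)Nc4ccc(C)cc4C)cccc23)cc(OC)c1` gives 1290 nM.
Compound 2 `COc1cc(Nc2ncnc3c(NC(=O)Nc4ccc([N+](=O)[O-])cc4)cccc23)cc(OC)c1` gives > 20000 nM, which is a limit of the assay.
Compound 3 `COc1cc(Nc2ncnc3c(NC(=O)Nc4ccc(C(F)(F)F)cc4[N+](=O)[O-])cccc23)cc(OC)c1` gives > 20000 nM, which is a limit of the assay.

All three compounds share one core and differ only in the aryl group on the urea. They were measured in a functional assay on RT-112 cells (Homo sapiens) for antiproliferative activity, read by MTT assay, with a stated time of 72 h; on this read-out higher numbers stand for weaker inhibition of growth and lower numbers for stronger inhibition of growth. Compound 2 sits at the limit of this assay and gives no number; this is the limit of > 20000 nM in this assay, at which 2 of the 3 values shown sit. Compound 1 is the only one of the three with a measured number.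

Compound 4 `CCOC(=O)c1ccc(NC(=O)Nc2cccc3c(Nc4cc(OC)cc(OC)c4)ncnc23)cc1` is the next compound. Its change from compound 2 is ethoxycarbonyl in place of nitro on an aromatic carbon.

Among the measured compounds shown here, only one measured step touches this part of the molecule: an at least 15-fold higher number from compound 1 to compound 2 (1.19 log units; beyond the scatter). That step ended at the limit, and compound 3, with a different aryl group, also ends at the limit, so nothing yet measured shows a group on this ring that brings the value back down from the limit. For the measured compounds named here, no measured step covers ethoxycarbonyl at all. The expectation for compound 4 is therefore cautious: an at least 1.6-fold lower number from compound 2 to compound 4 (0.22 log units; that floor lies within the scatter), with a fair chance that this assay again reports only a limit. The estimate for compound 4 is 12000 nM, in the range 3000 nM to 40000 nM.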

Compound 4, concentration for 50% growth inhibition: 317 nM
Compound 4: middle estimate off by 38-fold (1.58 log units), on the high side; measured number below the stated range.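

Ethoxycarbonyl in place of nitro on this aromatic carbon, para to a large group, gives an at least 63-fold lower number from compound 2 to compound 4 (1.79 log units; beyond the scatter) in this assay, the only step shown on this ring that comes back from the limit, and the two groups carry the same count of hydrogen-bond acceptors and donors, so those counts do not separate them. The 4-(ethoxycarbonyl)phenyl group also does better than 2,4-dimethylphenyl on the same amide-type nitrogen, with a 4.1-fold lower number from compound 1 to compound 4 (0.61 log units; beyond the scatter), so this urea aryl group can give stronger inhibition of growth than any other measured here. The true size of the step from nitro remains unknown, and only its floor can be read, because compound 2 stands at a limit and not at a number: the limit of > 20000 nM in this assay, at which 2 of the 4 values shown sit.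

From the compounds shown here alone, it remains open which part of the ethoxycarbonyl group matters, and a carboxylic acid, a methyl ester or a primary amide on the same carbon would help to separate the role of the carbonyl from that of the ethyl chain. Also open, going by these compounds, is whether a longer chain on the ester, or an amine in its place, would keep or lose this growth inhibition.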